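Amide nitrogen substituent variation in a three-compound series

The compounds below may be only part of what the source reports. "The series", "measured", "known", "first", "only" and "open" are said of these compounds alone.

Measured so far:
compound 1 `COc1cc2cc(C(=O)NCc3ccc(F)cc3)c(=O)oc2cc1OCCCOc1no[n+]([O-])c1S(=O)(=O)c1ccccc1`: 770 nM
compound 2 `COc1ccc(CNC(=O)c2cc3cc(OC)c(OCCCOc4no[n+]([O-])c4S(=O)(=O)c4ccccc4)cc3oc2=O)cc1`: 780 nM
compound 3 `COc1cc2cc(C(=O)Nc3ccccc3)c(=O)oc2cc1OCCCOc1no[n+]([O-])c1S(=O)(=O)c1ccccc1`: 1190 nM

All three numbers come from a functional assay on MDA-MB-231 cells (Homo sapiens) for inhibition, read by MTT assay, with a stated time of 48 h; a lower number here means a stronger inhibitor, a higher number a weaker inhibitor. Compound 2 gives the second highest of the three; its nearest neighbour is compound 1 and its furthest is compound 3, and neither gap leaves the scatter: a 1.0-fold higher number from compound 1 to compound 2 (0.01 log units; within the scatter), a 1.5-fold higher number from compound 2 to compound 3 (0.18 log units; within the scatter).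

Compound 4 `COc1ccc(NC(=O)c2cc3cc(OC)c(OCCCOc4no[n+]([O-])c4S(=O)(=O)c4ccccc4)cc3oc2=O)cc1` is not yet measured. It differs from compound 2 by 4-methoxyphenyl in place of 4-methoxybenzyl on an amide-type nitrogen. Going by the values given here, two measured steps bear on this, both putting phenyl in place of a benzyl group on the amide-type nitrogen: a 1.5-fold higher number from compound 1 to compound 3 (0.19 log units; within the scatter) and a 1.5-fold higher number from compound 2 to compound 3 (0.18 log units; within the scatter), each within the scatter. A step of that size is therefore expected, a 1.4-fold higher number from compound 2 to compound 4 (0.15 log units; within the scatter), without confidence that it exceeds the scatter. Compound 4 is estimated at 1100 nM, within 600 nM to 2200 nM.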

Compound 4, half-maximal inhibitory concentration: 730 nM
The estimate for compound 4 lay 1.5-fold (0.18 log units) above the measured number, and the stated range covers the measured number.
By their numbers in this assay, from the lowest: compounds 4, 1, 2 and 3 (each within the scatter of the next).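

In this assay, 4-methoxyphenyl on the amide-type nitrogen cannot be told apart from either benzyl group (a 1.1-fold lower number from compound 2 to compound 4 (0.03 log units; within the scatter); a 1.1-fold lower number from compound 1 to compound 4 (0.02 log units; within the scatter)). Methoxy in place of hydrogen on an aromatic carbon of the phenyl group also stays within the scatter (a 1.6-fold lower number from compound 3 to compound 4 (0.21 log units; within the scatter)), so this nitrogen has so far tolerated all four aromatic groups without a resolved change. No evidence on the origin of these small steps is available.

Going by these compounds, whether a carboxylic acid, a basic amine or a longer chain carrying the aromatic ring on this nitrogen would give a step beyond the scatter remains open.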